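Hydroxy-methoxyphenyl in place of the halogenated ring on the hydrazone

The source may report more compounds than this note shows. Statements on the series, on what has been measured and on what is new or still open speak of the compounds shown alone.

Measured so far:
compound 1, `CN(C)CCn1cnnc1-c1cc(Oc2ccc(NC(=O)N/N=C/c3c(Cl)cccc3Cl)cc2F)ccn1`, giving 280 nM in a functional assay on HT-29 cells (Homo sapiens) for cytotoxicity, read by MTT assay, with a stated time of 72 h; on this read-out lower numbers stand for stronger inhibition and higher numbers for weaker inhibition;
compound 2, `CN(C)CCn1cnnc1-c1cc(Oc2ccc(NC(=O)N/N=C/c3ccc(F)cc3F)cc2F)ccn1`, giving 960 nM;
compound 3, `CN(C)CCn1cnnc1-c1cc(Oc2ccc(NC(=O)N/N=C/c3ccc(F)cc3Cl)cc2F)ccn1`, giving 510 nM.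

Compound 3 stands second highest of the three numbers. Among the compounds with values here, the step of a 1.8-fold higher number from compound 1 to compound 3 (0.26 log units; within the scatter) and the step of a 1.9-fold lower number from compound 2 to compound 3 (0.27 log units; within the scatter) both lie within the scatter; only the step of a 3.4-fold higher number from compound 1 to compound 2 (0.54 log units; beyond the scatter) lies beyond it, and it is modest.

Compound 4, `COc1cc(/C=N/NC(=O)Nc2ccc(Oc3ccnc(-c4nncn4CCN(C)C)c3)c(F)c2)ccc1O`, differs from compound 3 by 4-hydroxy-3-methoxyphenyl in place of 2-chloro-4-fluorophenyl on a carbon with a double bond to nitrogen. Within the data shown here, none of the measured steps exchanges a halogenated ring for one bearing a hydroxy and a methoxy group; the three steps only vary halogens and span a modest range. Among the measured compounds shown here, with no direct precedent, a modest rise is expected for compound 4, a 2.0-fold higher number from compound 3 to compound 4 (0.29 log units; within the scatter), and compound 4 is estimated at 1000 nM, within 300 nM to 3500 nM.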

Compound 4, half-maximal inhibitory concentration: 120 nM
Compound 4: middle estimate off by 8.3-fold (0.92 log units), on the high side, and the stated range ends above it.
By their numbers in this assay, from the lowest: compound 4; then compounds 1, 3 and 2 (each within the scatter of the next, the first and the last beyond it).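

On the carbon with a double bond to nitrogen, a ring without halogen gives the lowest number of the series in this assay: 4-hydroxy-3-methoxyphenyl produces a 4.3-fold lower number from compound 3 to compound 4 (0.63 log units; beyond the scatter) and an 8.0-fold lower number from compound 2 to compound 4 (0.90 log units; beyond the scatter) and a 2.3-fold lower number from compound 1 to compound 4 (0.37 log units; beyond the scatter). The earlier compounds shown here varied only halogens, so they did not show that this position accepts a ring with hydroxy and methoxy groups. No measurement here accounts for the lower number.

The compounds shown leave open whether the hydroxy or the methoxy group carries the change. They also leave open how a ring bearing an amine or a carboxylic acid would read in this assay.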